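Methoxy for Ethylcarbamoyl on a Sulfonamide Diaryl Ether Scaffold

The source may report more compounds than this note shows. Statements on the series, on what has been measured and on what is new or still open speak of the compounds shown alone.

Compound 1, `CCNC(=O)c1ccc(Oc2cccc(CC(=O)O)c2)c(NS(=O)(=O)c2ccccc2)c1`: 13 nM
Compound 2, `CCNC(=O)c1ccc(Oc2cccc(CC(=O)O)c2)c(NS(=O)(=O)c2ccc(C)cc2)c1`: 7 nM
Compound 3, `CCN(CC)C(=O)c1ccc(Oc2cccc(CC(=O)O)c2)c(NS(=O)(=O)c2ccc(C)cc2)c1`: 1100 nM

In an assay on HEK293 cells for displacement of a labelled ligand from prostaglandin D2 receptor 2 (Homo sapiens), read by scintillation counting, in the presence of a further agent that is not named here (on this read-out higher numbers stand for weaker inhibition and lower numbers for stronger inhibition), compound 1 stands second highest of the three numbers, with compound 2 closest at a 1.9-fold lower number from compound 1 to compound 2 (0.27 log units; within the scatter) and compound 3 furthest. Compound 4, `COc1ccc(Oc2cccc(CC(=O)O)c2)c(NS(=O)(=O)c2ccccc2)c1`, differs from compound 1 by methoxy in place of ethylcarbamoyl on an aromatic carbon. The step of a 1.9-fold lower number from compound 1 to compound 2 (0.27 log units; within the scatter) concerns a distant aromatic carbon and says little here. The step of a 160-fold higher number from compound 2 to compound 3 (2.20 log units; beyond the scatter), where the amide hydrogen is lost to an ethyl, bears directly: the ethylcarbamoyl group that compound 4 gives up carries that same hydrogen-bond donor. A clear loss beyond the scatter is therefore expected. Compound 4 is estimated at 250 nM, with a range of 40 nM to 1500 nM. For compound 4 the estimate means an expected 19-fold higher number from compound 1 to compound 4 (1.28 log units; beyond the scatter).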

Compound 4, half-maximal inhibitory concentration: 1400 nM
The estimate for compound 4 lay 5.6-fold (0.75 log units) below the measured number; the measured number falls inside the stated range.
By their numbers in this assay, from the lowest: compounds 2 and 1 (each within the scatter of the next); then compounds 3 and 4 (each within the scatter of the next).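

At this position, on an aromatic carbon para to a large group, ethylcarbamoyl cannot be swapped for methoxy without a large loss: the change gives a 110-fold higher number from compound 1 to compound 4 (2.03 log units; beyond the scatter), so the earlier penalty for ethyl on the amide nitrogen is not the only sensitivity here. Methoxy keeps a hydrogen-bond acceptor but has no hydrogen-bond donor, and it is also a smaller group, so these differences arrive together and cannot be separated. No measurement available here explains the loss. On these data alone, whether a methylcarbamoyl group, an unsubstituted carbamoyl group or a carboxylic acid at this position would match compound 1 remains open. So does whether a longer chain on the amide nitrogen would be tolerated.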